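From Propyl to 4-Methylphenyl on an Aromatic Nitrogen

A few compounds are considered here, and "the series" means these few. Any claim that something is new, unique, unknown or untested is made for them only; others in the source may bear on it.

Compound 1 `CCCn1ccnc1-c1cc(OC)c(OC)c(OC)c1` was examined in a functional assay on MDA-MB-468 cells (Homo sapiens) for antiproliferative activity, read by MTT assay, with a stated time of 72 h; a lower number here means a stronger inhibitor, a higher number a weaker inhibitor. Compound 1 gives > 100000 nM, which is a limit of the assay and not a number. Compound 2 `COc1ccc(-n2ccnc2-c2cc(OC)c(OC)c(OC)c2)cc1[N+](=O)[O-]` also bears a six-membered aromatic ring of carbon only on that same nitrogen, and in this assay compound 2 gives 100 nM, a measured number.

Compound 3 `COc1cc(-c2nccn2-c2ccc(C)cc2)cc(OC)c1OC` keeps the core of compound 1 but carries 4-methylphenyl in place of propyl on an aromatic nitrogen. It has not yet been measured in this assay. On the strength of compound 2 at 100 nM, a large step towards stronger inhibition, well beyond the scatter, is expected. The estimated change is an at least 66-fold lower number from compound 1 to compound 3 (1.82 log units; beyond the scatter). Among the measured compounds shown here, no measured compound carries 4-methylphenyl, and the expected range stays wide. For compound 3 the estimated value is 1500 nM, with a range from 150 nM to 20000 nM.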

Compound 3, half-maximal inhibitory concentration: 400 nM
Estimate against measurement, compound 3: 3.8-fold (0.57 log units) above; low and high end bracket the measured number.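

Among the compounds shown here, the change from propyl to 4-methylphenyl on an aromatic nitrogen gives an at least 250-fold lower number from compound 1 to compound 3 (2.39 log units; beyond the scatter) in this assay, the first step here in which only this one place is altered. Compound 3 gives 400 nM with a ring that carries neither the methoxy nor the nitro group of compound 2, so a measured number at this position does not depend on those two groups. The true size of the step stays unknown because compound 1 is a limit and not a number: the limit of > 100000 nM in this assay, at which 1 of the 3 values shown sits.

The compounds shown do not separate the effect of the six-membered aromatic ring from that of its methyl, which plain phenyl on this nitrogen would address. They also leave open how a benzyl group or a longer chain such as hexyl would behave in place of propyl.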